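Chain length on the amine nitrogen: compound 1 to compound 4

This account rests on a few compounds, and the source may have more. Where it says the series, first, only, none or still open, it means among the compounds named here.

Compound 1 `CCCNC(=C\C(=O)/C=C/c1ccc(O)c(OC)c1)/C=C/c1ccc(O)c(OC)c1` gives > 25000 nM in an ADME assay on Caco-2 cells (Homo sapiens) for inhibition, read by sulforhodamine B assay, with a stated time of 72 h; a lower number here means a stronger inhibitor, a higher number a weaker inhibitor.
Compound 2 `CCC(C)NC(=C\C(=O)/C=C/c1ccc(OC(C)=O)c(OC)c1)/C=C/c1ccc(OC(C)=O)c(OC)c1` gives > 25000 nM in this assay.
Compound 3 `COc1cc(/C=C/C(=O)/C=C(/C=C/c2ccc(OC(C)=O)c(OC)c2)NC2CCCCC2)ccc1OC(C)=O` gives > 25000 nM in this assay.

Each of these three values is a limit of this assay, not a number. Compound 1 therefore stands only at that limit, with no number of its own. Among the measured compounds shown here, the single piece of evidence on the series is the limit of > 25000 nM in this assay, at which 3 of the 3 values shown sit. For the measured compounds named here, the one measured step, a step that the two limits leave unreadable from compound 2 to compound 3, is unreadable between its two limits.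

Compound 4 `CCCCNC(=C\C(=O)/C=C/c1ccc(O)c(OC)c1)/C=C/c1ccc(O)c(OC)c1` differs from compound 1 by methyl in place of hydrogen on a saturated chain carbon, three bonds along the chain from an amine nitrogen. Going by the values given here, no measured step covers this change, and the one step that exists tells nothing of size or direction. Compound 4 is therefore expected to remain at the limit, with a step that the limit leaves unreadable from compound 1 to compound 4 as the expected step. The estimate for compound 4 is 40000 nM, in the range 15000 nM to 120000 nM.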

Compound 4, half-maximal inhibitory concentration: > 25000 nM
Compound 4 gave a limit, no number; the forecaster's own chance of this, stated with the estimate: 90%; the middle value is on the limit's open side.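

Compound 1 and compound 4 both stand only at a limit in this assay, so no step can be read between them. The compounds shown leave open whether chain length on the amine nitrogen changes inhibition at all.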